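The source may report more compounds than this note shows. Statements on the series, on what has been measured and on what is new or still open speak of the compounds shown alone.

Among the measured compounds shown here, in a physicochemical assay for solubility, at pH 7.4 (a higher number here means a more soluble compound, a lower number a less soluble compound), compound 1 (`Cc1cc(NC(=O)Nc2ccc(O)cc2)c2ccccc2n1`) gives 100 nM and compound 2 (`Cc1cc(NC(=O)Nc2ccc(C(=O)O)cc2)c2ccccc2n1`) gives 9300 nM as the higher of the two numbers so far. For the measured compounds named here, the one measured step is a 93-fold higher number from compound 1 to compound 2 (1.97 log units; beyond the scatter) for carboxy in place of hydroxy on an aromatic carbon. Compound 3 (`COc1ccc(NC(=O)Nc2cc(C)nc3ccccc23)cc1`) has methoxy in place of carboxy on an aromatic carbon, para to a large group (methoxy in place of carboxy on an aromatic carbon). Going by the values given here, only that single large step bears on this change, and in it carboxy came in, whereas here carboxy leaves. With compound 1 at 100 nM as the nearest guide, a large step down of similar size is expected. Among the compounds with values here, no compound with methoxy has been measured yet, so the range stays wide. The estimated change is a 120-fold lower number from compound 2 to compound 3 (2.07 log units; beyond the scatter) on this reading. In this assay the estimate for compound 3 is 80 nM with an expected range of 20 nM to 350 nM around it.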

Compound 3, solubility: 19800 nM
The estimate for compound 3 lay 250-fold (2.39 log units) below the measured number; the whole stated range lies below it.
By their numbers in this assay, from the lowest: compound 1; then compound 2; then compound 3.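

Within these three compounds, a high number in this assay does not depend on carboxy at this place, since methoxy in place of carboxy gives a 2.1-fold higher number from compound 2 to compound 3 (0.33 log units; beyond the scatter) and so keeps the number high and even raises it modestly. Adding only a methyl to the oxygen of compound 1 gives a 200-fold higher number from compound 1 to compound 3 (2.30 log units; beyond the scatter), a large step that leaves compound 1 far below both other compounds and shows that its hydroxy, not the lack of carboxy, marks the low end of this short series. Nothing measured here explains why these numbers fall as they do.

The three groups shown do not settle whether the high numbers are the rule at this place or hydroxy alone is the exception. An amine, a plain hydrogen or a longer chain such as ethoxy could land near compound 3 or near compound 1.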